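Swapping isopropyl for 4-bromophenyl on a carbonyl carbon

The source may report more compounds than this note shows. Statements on the series, on what has been measured and on what is new or still open speak of the compounds shown alone.

Compound 1 `COc1ccc(/C=C/C(=O)c2ccc(OC)c3c2OC(C)(C)C=C3)cc1OCC=C(C)C`: > 10000 nM
Compound 2 `COc1ccc(/C=C/C(=O)c2ccc(OC)c3c2OC(C)(C)C=C3)cc1OCCCN(C)C`: 4100 nM
Compound 3 `COc1ccc(/C=C/C(=O)c2ccc(OC)c3c2OC(C)(C)C=C3)cc1OC(=O)C(C)C`: 310 nM

These are readings in a functional assay on A-375 cells (Homo sapiens) for cytotoxicity, read by MTT assay (a lower number here means a stronger inhibitor, a higher number a weaker inhibitor), and the three compounds differ only in the group on an oxygen on an aromatic ring. Compound 1 gives > 10000 nM, which is a limit and not a number. Compound 3 stands lowest with 310 nM and is the strongest inhibitor of the three. The measured gaps to it are large: a 13-fold lower number from compound 2 to compound 3 (1.12 log units; beyond the scatter), and an at least 32-fold lower number from compound 1 to compound 3 (1.50 log units; beyond the scatter).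

Compound 4 `COc1ccc(/C=C/C(=O)c2ccc(OC)c3c2OC(C)(C)C=C3)cc1OC(=O)c1ccc(Br)cc1` keeps the carbonyl of compound 3 but has 4-bromophenyl in place of isopropyl on a carbonyl carbon. Going by the values given here, no measured step changes the group on that carbonyl carbon, so the data give no direct guide to its size. The two large steps into compound 3 (a 13-fold lower number from compound 2 to compound 3 (1.12 log units; beyond the scatter) and an at least 32-fold lower number from compound 1 to compound 3 (1.50 log units; beyond the scatter)) suggest that compound 4 should stay nearer compound 3 than compound 2, since it also has the carbonyl on that oxygen. Still, the entering group is untried, so a modest move towards a higher number is expected, with wide uncertainty. The expected change is a 2.3-fold higher number from compound 3 to compound 4 (0.35 log units; beyond the scatter). For compound 4 the estimate is 700 nM, with an expected range from 150 nM to 3000 nM.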

Compound 4, half-maximal inhibitory concentration: 420 nM
Compound 4: the middle estimate sits 1.7-fold (0.22 log units) above what was measured; measured number inside the range.
By their numbers in this assay, from the lowest: compounds 3 and 4 (each within the scatter of the next); then compound 2. At a limit, above all of these: compound 1.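

In this assay, the step that swaps isopropyl for 4-bromophenyl on a carbonyl carbon, which brings in a six-membered aromatic ring, is a 1.4-fold higher number from compound 3 to compound 4 (0.13 log units; within the scatter), so this position tolerates a much bigger group with no readable change in the number. Going by these compounds alone, until now only one group had stood on that carbonyl carbon; with two, the low numbers no longer rest on isopropyl alone, and compound 4 stays well apart from the compounds without a carbonyl on that oxygen, with a 9.8-fold lower number from compound 2 to compound 4 (0.99 log units; beyond the scatter) and an at least 23-fold lower number from compound 1 to compound 4 (1.37 log units; beyond the scatter). The second of those steps starts from a limit and not a number, and compound 1 remains only that: the limit of > 10000 nM in this assay, at which 1 of the 4 values shown sits.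

On these data alone, only isopropyl and 4-bromophenyl stand on the carbonyl carbon here, so it remains open how a longer chain, a phenyl without bromine, or a phenyl carrying a carboxylic acid would read. Also open, as far as these compounds go, is what a plain hydroxyl on the aromatic ring, with neither a chain nor a carbonyl on that oxygen, would give, which would help show whether the carbonyl itself matters.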